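The source may hold more compounds than are shown below. What is called first, only, known or untested is meant among the compounds shown, and "the series" means these compounds.

Compound 1 `CCOC(=O)c1c(-c2c(Cl)c3ccccc3oc2=O)nn(-c2ccc(Br)cc2)c1C(=O)OCC` gives 30000 nM in a functional assay on A549 cells (Homo sapiens) for cytotoxicity, read by MTT assay, with a stated time of 48 h (a lower number here means a stronger inhibitor, a higher number a weaker inhibitor), the lowest of the three numbers in hand. Compound 2 `CCOC(=O)c1c(-c2c(Cl)c3cc(C)ccc3oc2=O)nn(-c2ccccc2)c1C(=O)OCC` gives 108000 nM and compound 3 `CCOC(=O)c1c(-c2c(Cl)c3cc(C)ccc3oc2=O)nn(-c2cccc(C)c2)c1C(=O)OCC` gives 115000 nM in this assay; both differ from compound 1 in more than one place, so no single-point comparison to compound 1 exists. Among the measured compounds shown here, the only one-place step measured, a 1.1-fold higher number from compound 2 to compound 3 (0.03 log units; within the scatter), is a methyl for hydrogen swap on an aromatic carbon and does not touch the position altered here. Compound 4 `CCOC(=O)c1c(-c2cc3ccccc3oc2=O)nn(-c2ccc(Br)cc2)c1C(=O)OCC` differs from compound 1 by hydrogen in place of chloro on an aromatic carbon. For the measured compounds named here, no measured step bears directly on this change, so the expectation for compound 4 is no step beyond the scatter, a 1.3-fold higher number from compound 1 to compound 4 (0.12 log units; within the scatter), with a modest lean toward a higher number. Compound 4 is therefore estimated at 40000 nM, with a range of 15000 nM to 110000 nM.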

Compound 4, half-maximal inhibitory concentration: 100000 nM
Compound 4: middle estimate off by 2.5-fold (0.40 log units), on the low side; the measured number falls inside the stated range.
By their numbers in this assay, from the lowest: compound 1; then compounds 4, 2 and 3 (each within the scatter of the next).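

In this assay the chloro on this aromatic carbon, opposite the ring oxygen, matters: hydrogen in its place gives a 3.3-fold higher number from compound 1 to compound 4 (0.52 log units; beyond the scatter), the first one-place step read at this position and one beyond the scatter. The step is read on the core of compound 1 alone, and nothing measured here accounts for it.

Going by these compounds, whether fluoro, methoxy or an amine at this position would keep the lower number stays open. So does whether the same step would appear on the core of compound 2.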